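The compounds below may be only part of what the source reports. "The series", "measured", "known", "first", "only" and "open" are said of these compounds alone.

Three compounds share one core: a benzamide bearing an aminophenyl group, linked through a thioester of a dithiocarbamate to a nitrogen ring. In a functional assay on A-375 cells (Homo sapiens) for antiproliferative activity, read by CCK-8 assay, with a stated time of 72 h, tested at 2 uM (a lower number here means a weaker effect, a higher number a stronger effect of the compound at the concentration tested), compound 3 `Nc1ccccc1NC(=O)c1ccc(CSC(=S)N2CCN(c3ccccc3F)CC2)cc1` gives 18.7%. Of the three numbers shown this is the smallest, though the gap to its nearest neighbour is within the scatter: compound 2 `Nc1ccccc1NC(=O)c1ccc(CSC(=S)N2CCN(c3ccc(F)cc3)CC2)cc1` gives 20.9% in this assay, and the change a number 2.2 percentage points lower from compound 2 to compound 3 (within the scatter) cannot be read as a real difference. Only compound 1 `CC1CCN(C(=S)SCc2ccc(C(=O)Nc3ccccc3N)cc2)CC1`, which gives 32.7% in this assay, stands beyond the scatter above compound 3.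

Compound 4 `Nc1ccccc1NC(=O)c1ccc(CSC(=S)N2CCN(c3ccccc3)CC2)cc1` differs from compound 3 in one place: hydrogen in place of fluoro on an aromatic carbon. Within the data shown here, the only measured step that touches the same part of the molecule is the one from compound 2 to compound 3, which moved the fluoro between two positions on the same phenyl ring and stayed within the scatter. Among the measured compounds shown here, no step that removes a fluoro altogether has been measured, so the expectation rests on that one small step. The effect of the step from compound 3 to compound 4 is therefore expected to be small, a number 1.3 percentage points higher from compound 3 to compound 4 (within the scatter), with no direction beyond the scatter. Compound 4 is estimated to give 20% in this assay, in a range from 10% to 31%.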

Compound 4, a percentage reported as inhibition, at one concentration (the size of the read-out at that concentration, not a potency): 27.5%
Beside the measured number, compound 4's estimate is 7.5 percentage points below it, and the stated range covers the measured number.
By their numbers in this assay, from the lowest: compounds 3, 2, 4 and 1 (each within the scatter of the next, the first and the last beyond it).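

Among these compounds, compound 4 gives the first view of this phenyl ring with no fluoro at all, where the earlier compounds only showed the fluoro in two different positions. In this assay, replacing the fluoro with hydrogen gives a number 8.8 percentage points higher from compound 3 to compound 4 (within the scatter), and the same replacement on the other fluorinated compound gives a number 6.6 percentage points higher from compound 2 to compound 4 (within the scatter). Both steps stay within the usual scatter, so the unsubstituted phenyl compound cannot be told apart from either fluorinated one, and the data show no measurable role for this fluoro in this assay; no supporting measurement is available to explain the numbers shown.

It remains open whether any group on this aromatic carbon could shift the read-out beyond the scatter, since a small fluoro and a hydrogen are the only two options shown there, and a larger group such as methoxy, chlorine or trifluoromethyl would put that to a stronger test. Going by these compounds, it is also open whether a benzyl group in place of the phenyl on the ring nitrogen would give a clearer difference.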